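Notes on three measured amines and one open analogue

This account rests on a few compounds, and the source may have more. Where it says the series, first, only, none or still open, it means among the compounds named here.

All three measured compounds were read in an ADME assay on HL-60 cells (Homo sapiens) for cytotoxicity, read by MTT assay, with a stated time of 24 h; a lower number here means a stronger inhibitor, a higher number a weaker inhibitor:

- compound 1 `CN1CCC=C(c2ccc(CN(C)C/C=C/c3ccccc3)cc2)C1`: > 50000 nM, a limit of the assay
- compound 2 `CN1CCC=C(c2ccc(CN(C)CCCc3ccccc3)cc2)C1`: > 50000 nM, a limit of the assay
- compound 3 `CN(C/C=C/c1ccccc1)Cc1ccc(C2CCCN(C)C2)cc1`: > 50000 nM, a limit of the assay

The change from compound 1 to compound 2 is phenethyl in place of 2-phenylethenyl on a saturated chain carbon bound to an amine nitrogen. Its step in this assay is a step that the two limits leave unreadable from compound 1 to compound 2, so the size cannot be read. The two cores differ as a group of 7 heavy atoms (6 carbon, 1 nitrogen; one six-membered non-aromatic ring with 1 hetero atom) in place of a group of 7 heavy atoms (6 carbon, 1 nitrogen; one six-membered non-aromatic ring with 1 hetero atom), on an aromatic carbon, and that step is a step that the two limits leave unreadable from compound 1 to compound 3, again without a readable size. What the three values share is the limit of > 50000 nM in this assay, at which 3 of the 3 values shown sit; none of them gives a number, so no ordering among compound 1, compound 2 and compound 3 can be drawn, and no pattern beyond these three is claimed.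

Compound 4 `CN(CCCc1ccccc1)Cc1ccc(C2CCCN(C)C2)cc1` is not yet measured. Among the compounds with values here, it differs from compound 3 by phenethyl in place of 2-phenylethenyl on a saturated chain carbon bound to an amine nitrogen, which is the same change as the one from compound 1 to compound 2, made on the same place in the same words, so the two occurrences are the same change. With compound 1 and compound 2 both at the limit and compound 3 also at the limit, the expectation for compound 4 is a step that the limit leaves unreadable from compound 3 to compound 4 in this assay, resting on a step that the two limits leave unreadable from compound 1 to compound 2 and on (the limit of > 50000 nM in this assay, at which 3 of the 3 values shown sit). The estimate for compound 4 in this assay is 70000 nM, with the expected range 30000 nM to 200000 nM, and most likely another limit rather than a number.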

Compound 4, half-maximal inhibitory concentration: > 50000 nM
Compound 4 was reported as a limit; the forecaster's own chance of this, stated with the estimate: 85%; the middle value is on the limit's open side.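

Compound 4 gives > 50000 nM in this assay as a limit of the assay, not a number. No new step can be read, since the steps reaching compound 4 from compound 3 and from compound 2 have no readable size. The compounds shown leave open any ordering among compound 1, compound 2, compound 3 and compound 4, and whether either change has any size in this assay at all: the limit of > 50000 nM in this assay, at which 4 of the 4 values shown sit.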